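The source may report more compounds than this note shows. Statements on the series, on what has been measured and on what is new or still open speak of the compounds shown alone.

Measured so far:
compound 1, `O=S(=O)(NCCCNCc1cccc2ccccc12)c1cc(C(F)(F)F)cc(C(F)(F)F)c1`: 2800 nM
compound 2, `O=S(=O)(NCCNCc1ccc(-c2ccccc2)cc1)c1cc(C(F)(F)F)cc(C(F)(F)F)c1`: 2700 nM
compound 3, `O=S(=O)(NCCCCCCNCc1ccc(Br)cc1)c1ccccc1Cl`: 13700 nM

All three were tested in a functional assay on MIA PaCa-2 cells (Homo sapiens) for inhibition, read by MTT assay, with a stated time of 72 h; a higher number here means a weaker inhibitor of growth, a lower number a stronger inhibitor of growth. Compound 1 gives 2800 nM, the second highest of the three numbers. Compound 2 gives 2700 nM, a number within the usual scatter of compound 1, so nothing separates the two. Compound 3 gives 13700 nM, a number beyond the scatter and higher than that of compound 1, so compound 3 is the weaker inhibitor of growth of that pair.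

Compound 4, `O=S(=O)(NCCCNCc1ccccc1Cl)c1cc(C(F)(F)F)cc(C(F)(F)F)c1`, has not yet been measured. It differs from compound 1 in one place: 2-chlorophenyl in place of naphthalen-1-yl on a saturated chain carbon bound to an amine nitrogen. For the measured compounds named here, no measured pair shows this particular change, so its effect is not known from these data. Going by the values given here, the larger aromatic groups of compound 1 and compound 2 give the lower numbers seen here, and the only compound with a smaller aromatic group, compound 3, gives the highest number, though its other parts differ as well. A modest rise, at or just beyond the scatter, is expected: the estimated step of a 2.0-fold higher number from compound 1 to compound 4 (0.29 log units; within the scatter) in this assay. Compound 4 is thus estimated at 5500 nM, with a likely range from 2000 nM to 15000 nM.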

Compound 4, concentration for 50% growth inhibition: 11000 nM
Compound 4: middle estimate off by 2.0-fold (0.30 log units), on the low side; the measured number falls inside the stated range.
By their numbers in this assay, from the lowest: compounds 2 and 1 (each within the scatter of the next); then compounds 4 and 3 (each within the scatter of the next).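

In this assay, putting 2-chlorophenyl in place of naphthalen-1-yl on a saturated chain carbon bound to an amine nitrogen gives a 3.9-fold higher number from compound 1 to compound 4 (0.59 log units; beyond the scatter), a step beyond the scatter. The earlier compounds shown here differed from one another in more than one place, so none of them could tie a change in growth inhibition to this position alone; this pair shows that the group held here matters while the rest of the molecule stays the same. No measurement at hand explains the rise.

This change removes one aromatic ring and brings in a chlorine at the same time, so the compounds shown cannot separate the two. As far as these compounds go, whether an unsubstituted phenyl or a naphthalen-2-yl at this position would give a number closer to that of compound 1 remains open.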